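Notes on the amine substituent: from compound 3 toward compound 4

The source may report more compounds than this note shows. Statements on the series, on what has been measured and on what is new or still open speak of the compounds shown alone.

In an assay on HEK293 cells for inhibition of Steryl-sulfatase (Homo sapiens), tested at 1 uM (a lower number here means a weaker effect, a higher number a stronger effect of the compound at the concentration tested), compound 1 `CCN(Cc1cccnc1)c1ccc(C(=O)N2CCc3ccc(OS(N)(=O)=O)cc3C2)cc1` gives 85.2%, and compound 2 `CCN(Cc1ccc(Br)cc1)c1ccc(C(=O)N2CCc3ccc(OS(N)(=O)=O)cc3C2)cc1` gives 95.9%. Compound 3 `NS(=O)(=O)Oc1ccc2c(c1)CN(C(=O)c1ccc(N3CCCCC3)cc1)CC2` gives 38.3%, the lowest of the three measured numbers; its distance to both others is beyond the scatter. The step of a number 46.9 percentage points lower from compound 1 to compound 3 (beyond the scatter) and the step of a number 57.6 percentage points lower from compound 2 to compound 3 (beyond the scatter) are both large, whereas a number 10.7 percentage points higher from compound 1 to compound 2 (beyond the scatter) is modest by comparison.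

Compound 4 `CCCN(CCC)c1ccc(C(=O)N2CCc3ccc(OS(N)(=O)=O)cc3C2)cc1` is not yet measured. It differs from compound 3 as follows: dipropylamino in place of piperidin-1-yl on an aromatic carbon. The two steps that bear on this position both run into compound 3 and both are large downward moves, so the reverse direction, away from piperidin-1-yl toward an open-chain amine, is expected to give back part of that loss. Compound 4, however, carries neither a pyridin-3-yl nor a 4-bromophenyl in the entering dipropylamino, so only a partial recovery is expected. The expected step is a number 21.7 percentage points higher from compound 3 to compound 4 (beyond the scatter), upward but smaller than the steps seen into compound 3. For compound 4 a value of 60% is estimated, with a range from 35% to 85%.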

Compound 4, a percentage reported as inhibition, at one concentration (the size of the read-out at that concentration, not a potency): 84.7%
Estimate against measurement, compound 4: 24.7 percentage points below; the measured number falls inside the stated range.
By their numbers in this assay, from the lowest: compound 3; then compounds 4 and 1 (each within the scatter of the next); then compound 2.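

In this assay the change from piperidin-1-yl to dipropylamino gives a number 46.4 percentage points higher from compound 3 to compound 4 (beyond the scatter) and so shows that a high number at this position is reached with a plain open-chain amine, with no aromatic ring on the nitrogen substituents. The pyridin-3-yl arm shows no gain over two propyl chains, with a number 0.5 percentage points lower from compound 1 to compound 4 (within the scatter) for that exchange, whereas the (4-bromobenzyl)(ethyl)amino group keeps a modest edge, with a number 11.2 percentage points lower from compound 2 to compound 4 (beyond the scatter) on the change to dipropylamino. No measurement at hand explains the gap between the ring and the open chain.

Still open, going by these compounds, is whether the low number belongs to the ring as such or to its size, which pyrrolidine, azepane or morpholine in place of piperidine would address. Also open, on these data alone, is how chain length acts, as diethylamino or dibutylamino would show, and whether the bromine or the benzyl carries the edge of compound 2.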